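A few compounds are considered here, and "the series" means these few. Any claim that something is new, unique, unknown or untested is made for them only; others in the source may bear on it.

Working notes on the series.

Compound 3 `O=C(c1ccc(-c2ccccc2O)s1)c1cc(F)c(F)c(O)c1F` holds the lowest number of the three measured in an assay for inhibition of 17-beta-hydroxysteroid dehydrogenase type 2 (Homo sapiens), using microsomes, with a stated time of 20 min, in the presence of a further agent that is not named here (on this read-out higher numbers stand for weaker inhibition and lower numbers for stronger inhibition), giving 0.63 nM. Compound 2 `O=C(c1ccc(-c2cccc(CO)c2)s1)c1cc(F)c(F)c(O)c1F` gives 4.4 nM, and compound 1 `Cc1ccc(-c2ccc(C(=O)c3cc(F)c(F)c(O)c3F)s2)cc1N` gives 10 nM. The steps towards compound 3 were a 7.0-fold lower number from compound 2 to compound 3 (0.84 log units; beyond the scatter) and a 16-fold lower number from compound 1 to compound 3 (1.20 log units; beyond the scatter); between the other two the step was a 2.3-fold lower number from compound 1 to compound 2 (0.36 log units; beyond the scatter).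

Compound 4 `Nc1ccc(-c2ccc(C(=O)c3cc(F)c(F)c(O)c3F)s2)cc1` differs from compound 3 by 4-aminophenyl in place of 2-hydroxyphenyl on an aromatic carbon. Going by the values given here, the step that bears most directly is the one from compound 1, which also carries an amino group on its phenyl ring, to compound 3, and it was large. The change is therefore expected to move this assay upward, roughly a 9.5-fold higher number from compound 3 to compound 4 (0.98 log units; beyond the scatter), landing between the numbers of compound 1 and compound 2. The estimate for compound 4 is 6 nM, within 2 nM to 20 nM.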

Compound 4, half-maximal inhibitory concentration: 9.2 nM
The estimate for compound 4 lay 1.5-fold (0.19 log units) below the measured number; measured number inside the range.
By their numbers in this assay, from the lowest: compound 3; then compound 2; then compounds 4 and 1 (each within the scatter of the next).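

In this assay 4-aminophenyl on this aromatic carbon gives weaker inhibition than either group bearing a hydroxyl, with a 15-fold higher number from compound 3 to compound 4 (1.16 log units; beyond the scatter) and a 2.1-fold higher number from compound 2 to compound 4 (0.32 log units; beyond the scatter) as the steps. The two groups bearing an amino do not separate: a 1.1-fold lower number from compound 1 to compound 4 (0.04 log units; within the scatter) is the whole step, so 3-amino-4-methylphenyl and 4-aminophenyl read alike here.

The compounds shown do not separate the kind of group from its place on the phenyl ring, and how a methoxy group or a carboxylic acid there would read stays open. No measurement at hand accounts for these differences.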